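Trading One Aryl Group on an Amide for Another

The compounds below may be only part of what the source reports. "The series", "measured", "known", "first", "only" and "open" are said of these compounds alone.

In a functional assay on T47D cells (Homo sapiens) for inhibition, read by CCK-8 assay, with a stated time of 72 h, tested at 1 uM (a higher number here means more inhibition of growth at the concentration tested, a lower number less inhibition of growth), compound 1 `CN(C)C(=O)c1cc2cnc(Nc3ccc(N)cn3)nc2n1C1CCCC1` gives 18.8%, while compound 2 `CN(C)C(=O)c1cc2cnc(Nc3ccc(NC(=O)C4(C(=O)Nc5ccccc5F)CC4)cc3)nc2n1C1CCCC1` gives 85.2%. Within the data shown here, compound 2 therefore holds the higher of the two numbers so far, and the gap lies beyond the scatter of repeated measurements. These two compounds differ in more than one place, so their gap cannot be assigned to any single group.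

The next compound, compound 3 `CN(C)C(=O)c1cc2cnc(Nc3ccc(NC(=O)C4(C(=O)Nc5ccc(C(F)(F)F)cc5)CC4)cc3)nc2n1C1CCCC1`, departs from compound 2 in one place only: 4-(trifluoromethyl)phenyl in place of 2-fluorophenyl on an amide-type nitrogen. Put simply, it has 4-(trifluoromethyl)phenyl in place of 2-fluorophenyl on an amide-type nitrogen. Among the measured compounds shown here, no tested pair yet isolates a single change, so there is no measured guide to the effect of this swap. Compound 2 at 85.2% leaves little room for growth inhibition to climb, which makes a small loss more likely than a large gain. The expected change is slight and downward, not beyond the scatter, with an estimated step of a number 7.2 percentage points lower from compound 2 to compound 3 (within the scatter). For compound 3 the expected value is 78%, with an estimated range of 55% to 93%.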

Compound 3, percent growth inhibition at one concentration: 29.6%
For compound 3 the middle estimate is 48.4 percentage points above the measured one; measured number below the stated range.
By their numbers in this assay, from the lowest: compound 1; then compound 3; then compound 2.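

Among these compounds, this pair is the first to isolate a single change. In this assay, replacing 2-fluorophenyl with 4-(trifluoromethyl)phenyl on an amide-type nitrogen gives a number 55.6 percentage points lower from compound 2 to compound 3 (beyond the scatter), so with the rest of the molecule held constant, the aryl group at this position has a large bearing on growth inhibition at the concentration tested. No available evidence bears on why this swap lowers the number.

The swap alters both the substituent on the ring and where it is attached, and this single pair cannot separate those two changes. It also leaves open how a plain phenyl group or a chlorophenyl group would compare at this position, and so whether the 2-fluorophenyl of compound 2 is unusually favourable or the 4-(trifluoromethyl)phenyl of compound 3 is unusually poor.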